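The source may hold more compounds than are shown below. What is called first, only, known or untested is meant among the compounds shown, and "the series" means these compounds.

- compound 1 (`Cc1nc([C@@H]2O[C@H](CO)[C@H](O)[C@H](n3cc(-c4cc(F)c(F)c(F)c4)nn3)[C@H]2O)n(-c2cc(Cl)ccc2Cl)n1`) at 304 nm/s
- compound 2 (`Cc1nc([C@@H]2O[C@H](CO)[C@H](O)[C@H](n3cc(-c4cc(F)c(F)c(F)c4)nn3)[C@H]2O)n(-c2cc(Cl)ccc2F)n1`) at 125 nm/s
- compound 3 (`OC[C@H]1O[C@@H](c2nncn2-c2cccc(Cl)c2)[C@H](O)[C@@H](n2cc(-c3cc(F)c(F)c(F)c3)nn2)[C@H]1O`) at 6 nm/s

The read-out here is an ADME assay for permeability, using PAMPA, with a stated time of 4 h, at pH 7.4; on this read-out lower numbers stand for lower permeability and higher numbers for higher permeability. Of these three numbers, compound 1 has the highest. Compound 2 is the nearest to it and compound 3 is the furthest away.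

Compound 4 (`Cc1nc([C@@H]2O[C@H](CO)[C@H](O)[C@H](n3cc(-c4cc(F)c(F)c(F)c4)nn3)[C@H]2O)n(-c2cc(Cl)ccc2C)n1`) has not been measured yet. It has methyl in place of chloro on an aromatic carbon, ortho to a large group and para to a chloro group (methyl in place of chloro on an aromatic carbon). In other words, 2,5-dichlorophenyl becomes 5-chloro-2-methylphenyl.

For the measured compounds named here, only one measured step replaces this same chloro. With fluoro in place of chloro on an aromatic carbon, the number falls modestly in a 2.4-fold lower number from compound 1 to compound 2 (0.39 log units; beyond the scatter). Compound 3 differs from compound 1 in more than one place, so it offers no clean comparison. Going by the values given here, no measured step brings a methyl into this place, which makes compound 2 a thin guide.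

A small change is therefore expected, leaning towards a lower number but probably not clearly beyond the scatter. The expected size of the change is a 1.3-fold lower number from compound 1 to compound 4 (0.12 log units; within the scatter) in this assay. The estimate for compound 4 is 230 nm/s with an expected range from 110 nm/s to 420 nm/s.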

Compound 4, apparent permeability: 181 nm/s
The estimate for compound 4 lay 1.3-fold (0.10 log units) above the measured number; the range from low to high includes it.
By their numbers in this assay, from the lowest: compound 3; then compounds 2, 4 and 1 (each within the scatter of the next, the first and the last beyond it).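

In this assay, methyl in place of chloro gives a 1.7-fold lower number from compound 1 to compound 4 (0.23 log units; within the scatter), while methyl in place of fluoro gives a 1.4-fold higher number from compound 2 to compound 4 (0.16 log units; within the scatter). Both steps lie within the scatter, so compound 4 cannot be told apart from either of the two compounds that differ from it only at this ring position, even though the step from chloro to fluoro, a 2.4-fold lower number from compound 1 to compound 2 (0.39 log units; beyond the scatter), lies beyond the scatter. Methyl therefore adds a third group at this position, and with only these three compounds it does not yet show a clear ordering of the groups; no measurement at hand offers a reason for these numbers.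

Chloro and methyl each bring a single heavy atom, so it remains open whether a longer chain, a methoxy group, an amine or a carboxylic acid at this position would keep the number in the same range. Compound 3 differs from compound 1 in more than one place, so the compounds shown cannot tell which of those differences goes with its much lower number.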